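Swapping the Aryl Group on the Triazole Nitrogen

The source may hold more compounds than are shown below. What is called first, only, known or untested is meant among the compounds shown, and "the series" means these compounds.

Compound 1 `COc1ccc(/C=C\C(=O)O)c(OCc2cn(-c3ccc(C#N)cc3)nn2)c1CC=C(C)C` carries a 4-cyanophenyl group on an aromatic nitrogen of the shared core. In a functional assay on COLO 205 cells (Homo sapiens) for cytotoxicity, read by MTT assay, with a stated time of 24 h (on this read-out higher numbers stand for weaker inhibition and lower numbers for stronger inhibition), compound 1 gives 32000 nM, a weak effect on this read-out. Compound 2 `COc1ccc(/C=C\C(=O)O)c(OCc2cn(-c3cccnc3Cl)nn2)c1CC=C(C)C` bears a 2-chloropyridin-3-yl group on that same aromatic nitrogen, but in this assay compound 2 is recorded as "not determined" (no result reported), so no number places it against compound 1. Compound 3 `COc1ccc(/C=C\C(=O)O)c(OCc2cn(-c3ccccc3C#N)nn2)c1CC=C(C)C` is the next member of the set: it differs from compound 2 by 2-cyanophenyl in place of 2-chloropyridin-3-yl on an aromatic nitrogen. With no number for compound 2 and no measured step between any two of these compounds, there is no basis for expecting a step of a particular size or direction in this assay from this change, and a result within the usual scatter of the value seen for compound 1 is the plainest starting point. Compound 3 is therefore expected to give about 30000 nM in this assay, within a range from 10000 nM to 100000 nM.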

Compound 3, half-maximal inhibitory concentration: 3200 nM
Estimate against measurement, compound 3: 9.4-fold (0.97 log units) above; measured number outside the range, below it.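

In this assay, this position now has its first measured step, a 10-fold lower number from compound 1 to compound 3 (1.00 log units; beyond the scatter), with 2-cyanophenyl in place of 4-cyanophenyl on the aromatic nitrogen. Both groups are cyanophenyl groups, so the read-out at this position depends on where the nitrile sits on the phenyl ring, and not only on which kind of group is attached. No measurement offered here explains the step, so its cause stays unknown.

Going by these compounds, the step from compound 2 to compound 3 cannot be read, so the place of the 2-chloropyridin-3-yl group relative to the two cyanophenyl groups remains unknown. Also open, on these data alone, is how the read-out would respond to a plain phenyl group, or to a phenyl group carrying an amine or a carboxylic acid instead of the nitrile.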